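Trifluoromethyl for trifluoromethoxy: expectation for compound 3

The source may report more compounds than this note shows. Statements on the series, on what has been measured and on what is new or still open speak of the compounds shown alone.

Two members of the series carry numbers in an assay on isolated protein for inhibition of DNA topoisomerase 1 (Homo sapiens), with a stated time of 30 min, tested at 20 uM; on this read-out lower numbers stand for a weaker effect and higher numbers for a stronger effect at the one concentration tested. Compound 1 `Cc1cccc(-c2nc3ccc(C)cc3c(=O)[nH]2)c1` gives 12.7%. Compound 2 `CCN(CC)c1ccc2nc(-c3ccccc3OC(F)(F)F)[nH]c(=O)c2c1` gives 0%, which is the lowest of the two numbers; its nearest neighbour, compound 1, stands higher by a gap beyond the usual scatter. Within the data shown here, no pair of measured compounds differs in a single place, so no measured step is available to calibrate the change considered here.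

Compound 3 `CCN(CC)c1ccc2nc(-c3ccccc3C(F)(F)F)[nH]c(=O)c2c1` differs from compound 2 in one place: trifluoromethyl in place of trifluoromethoxy on an aromatic carbon. The rest of the molecule, including the diethylamino group, is kept.

Among the measured compounds shown here, since no measured step covers a trifluoromethyl-for-trifluoromethoxy exchange, the expectation rests on compound 2 alone. Compound 3 is expected to give 5%, with a range from 0% to 18%. The step of a number 5 percentage points higher from compound 2 to compound 3 (within the scatter) is expected to be small, in no clear direction, and within the scatter, because compound 2 already sits at 0% in this assay and the read-out cannot fall lower.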

Compound 3, a percentage reported as inhibition, at one concentration (the size of the read-out at that concentration, not a potency): 13.3%
Compound 3: the middle estimate sits 8.3 percentage points below what was measured; the measured number falls inside the stated range.
By their numbers in this assay, from the lowest: compound 2; then compounds 1 and 3 (each within the scatter of the next).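

Trifluoromethyl in place of trifluoromethoxy on an aromatic carbon, ortho to a large group, gives the first single-place step in the series, read in this assay as a number 13.3 percentage points higher from compound 2 to compound 3 (beyond the scatter). With the diethylamino group and the shared core kept, this one position is therefore able to move the read-out, something compound 2 alone could not show, although compound 3 at 13.3% still gives only a small effect at a single concentration and this number is not a potency. No measurement of any property accompanies the step, so the data offer no explanation for it.

The compounds shown leave open whether the step belongs to trifluoromethyl itself or would also appear with a plain methyl, a methoxy or a chlorine at the same place, and so whether trifluoromethoxy lowers the read-out or trifluoromethyl raises it. They also leave open whether the same exchange carries the same step when the diethylamino group gives way to another amine, such as a morpholine, or to a carboxylic acid.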